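The compounds below may be only part of what the source reports. "The series", "measured", "known", "first", "only" and "open" are said of these compounds alone.

Series notes. In a functional assay on isolated protein for agonist activity at Glucose-dependent insulinotropic receptor (Rattus norvegicus), read by HTRF and cAMP accumulation (a lower number here means that less compound is needed, a higher number that more compound is needed for the effect), compound 1 `CC(C)(C)OC(=O)N1CCC(O[C@H]2CC[C@@H](Oc3ccc(S(C)(=O)=O)cc3)CC2)CC1` gives 1390 nM, compound 2 `CC(C)OC(=O)N1CCC(O[C@H]2CC[C@H](Oc3ccc(S(C)(=O)=O)nc3)CC2)CC1` gives 201 nM and compound 3 `CC(C)OC(=O)N1CCC(O[C@H]2CC[C@H](Oc3cnc(S(C)(=O)=O)cn3)CC2)CC1` gives 119 nM. Compound 3 holds the lowest of the three numbers: the step of a 1.7-fold lower number from compound 2 to compound 3 (0.23 log units; within the scatter) keeps compound 2 and compound 3 within the scatter of each other, whereas the gap to compound 1 lies beyond it, although no single change separates compound 1 from compound 3. Compound 4 `C[C@@H](CF)OC(=O)N1CCC(O[C@H]2CC[C@H](Oc3cnc(S(C)(=O)=O)cn3)CC2)CC1` carries fluoro in place of hydrogen on a saturated chain carbon, two bonds along the chain from an oxygen next to a carbonyl group. Among the compounds with values here, no measured step touches this part of the molecule; the one measured step concerns the aryl end. With nothing bearing on the carbamate chain, no shift beyond the scatter is expected in this assay, and the step of a 1.0-fold higher number from compound 3 to compound 4 (0.00 log units; within the scatter) is the estimate. Compound 4 is expected to give 120 nM, within 45 nM to 320 nM.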

Compound 4, half-maximal effective concentration: 356 nM
Compound 4: middle estimate off by 3.0-fold (0.47 log units), on the low side; measured number above the stated range.
By their numbers in this assay, from the lowest: compounds 3, 2 and 4 (each within the scatter of the next, the first and the last beyond it); then compound 1.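

The carbamate chain is not silent in this assay, since with the aryl end unchanged, fluoro in place of hydrogen gives a 3.0-fold higher number from compound 3 to compound 4 (0.48 log units; beyond the scatter). Within the data shown here, this is the first reading at this position, and it shows that one added fluorine on the isopropyl group, now 1-(fluoromethyl)ethyl, is enough for a modest step beyond the scatter. Nothing available here accounts for the shift.

Still open, as far as these compounds go, is whether a methyl or hydroxyl group on the same chain carbon would give a similar step, or whether it is specific to fluoro. Also open, from the compounds shown here alone, is whether the step carries over to the 6-(methylsulfonyl)pyridin-3-yl end of compound 2.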